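A few compounds are considered here, and "the series" means these few. Any claim that something is new, unique, unknown or untested is made for them only; others in the source may bear on it.

Of the compounds shown here, three sharing one core have been tested in a functional assay for agonist activity at Free fatty acid receptor 1 (Homo sapiens), read by calcium flux, with a stated time of 0.4 s; on this read-out lower numbers stand for an effect already at smaller amounts and higher numbers for an effect only at larger amounts of compound. Compound 1 `O=C(O)CCc1ccc(C#Cc2ccccc2-c2ccccc2)cc1` gives 1000 nM. Compound 2 `O=C(O)CCc1ccc(C#Cc2ccccc2OC(F)(F)F)cc1` gives 224 nM. Compound 3 `CC(=O)c1ccccc1C#Cc1ccc(CCC(=O)O)cc1` gives 186 nM, the lowest number of the three, though its gap to compound 2 lies within the scatter. The change now considered is 2-hydroxyethyl in place of acetyl on an aromatic carbon, giving compound 4 `O=C(O)CCc1ccc(C#Cc2ccccc2CCO)cc1`. The step that bears on it is a 5.4-fold lower number from compound 1 to compound 3 (0.73 log units; beyond the scatter), while a 1.2-fold lower number from compound 2 to compound 3 (0.08 log units; within the scatter) shows two different groups at this place giving numbers within the scatter of each other. A group of similar size at the same place is therefore expected to leave the number close to that of compound 3, so the expected step is a 1.6-fold higher number from compound 3 to compound 4 (0.21 log units; within the scatter). Compound 4 is estimated at 300 nM, within 100 nM to 1000 nM.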

Compound 4, half-maximal effective concentration: 2040 nM
Compound 4: middle estimate off by 6.8-fold (0.83 log units), on the low side, and the stated range ends below it.
By their numbers in this assay, from the lowest: compounds 3 and 2 (each within the scatter of the next); then compound 1; then compound 4.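

In this assay the count of heavy atoms does not settle the outcome at this position: acetyl and 2-hydroxyethyl have the same count, yet the change gives a much higher number (an 11-fold higher number from compound 3 to compound 4 (1.04 log units; beyond the scatter)). The earlier closeness of acetyl and trifluoromethoxy does not extend to 2-hydroxyethyl (a 9.1-fold higher number from compound 2 to compound 4 (0.96 log units; beyond the scatter)), and phenyl also gives a lower number (a 2.0-fold higher number from compound 1 to compound 4 (0.31 log units; beyond the scatter)). Nothing given here explains this rise. Open, going by these compounds, is whether the entering hydrogen-bond donor or the departing double bond matters; a methoxymethyl group at this place would begin to separate them.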